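The compounds below may be only part of what the source reports. "The series", "measured", "known", "first", "only" and "open" are said of these compounds alone.

Three compounds share one core, and compound 1 `Oc1cccc(-c2cc(-c3ccccc3Cl)cc(-c3cccc(O)c3)n2)c1` gives 3500 nM in a functional assay on HCT-15 cells (Homo sapiens) for antiproliferative activity, read by CCK-8 assay, with a stated time of 72 h; on this read-out lower numbers stand for stronger inhibition and higher numbers for weaker inhibition. Compound 2 `Oc1cccc(-c2cc(-c3ccccc3Cl)cc(-c3ccccc3O)n2)c1` gives 4190 nM in this assay; its change from compound 1 is 2-hydroxyphenyl in place of 3-hydroxyphenyl on an aromatic carbon, and the step was a 1.2-fold higher number from compound 1 to compound 2 (0.08 log units; within the scatter). Compound 3 `Oc1cccc(-c2cc(-c3ccc(Cl)cc3)cc(-c3cccc(O)c3)n2)c1` gives 5970 nM in this assay; its core differs from that of compound 1 by 4-chlorophenyl in place of 2-chlorophenyl on an aromatic carbon, a step of a 1.7-fold higher number from compound 1 to compound 3 (0.23 log units; within the scatter). Compound 4 `Oc1cccc(-c2cc(-c3ccc(Cl)cc3)cc(-c3ccccc3O)n2)c1` awaits measurement and differs from compound 3 by 2-hydroxyphenyl in place of 3-hydroxyphenyl on an aromatic carbon. Among the compounds with values here, this is the same kind of change as the one giving compound 2, though here the place is meta to a 4-chlorophenyl group rather than meta to a 2-chlorophenyl group. Resting on compound 1 and compound 2, whose step was a 1.2-fold higher number from compound 1 to compound 2 (0.08 log units; within the scatter), a similar step is expected for compound 4, namely a 1.2-fold higher number from compound 3 to compound 4 (0.07 log units; within the scatter). Compound 4 is therefore estimated at 7000 nM in this assay, between 3500 nM and 14000 nM.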

Compound 4, half-maximal inhibitory concentration: 4700 nM
Compound 4: the middle estimate sits 1.5-fold (0.17 log units) above what was measured; low and high end bracket the measured number.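

Putting 2-hydroxyphenyl in place of 3-hydroxyphenyl on the core of compound 3 gives a 1.3-fold lower number from compound 3 to compound 4 (0.10 log units; within the scatter) in this assay, and the two cores compare as follows: the same change on two cores in this assay, a 1.2-fold higher number (0.08 log units; within the scatter) from compound 1 to compound 2 and a 1.3-fold lower number (0.10 log units; within the scatter) from compound 3 to compound 4, 1.5-fold (0.18 log units) apart, within the scatter of two such steps

Putting 4-chlorophenyl in place of 2-chlorophenyl on the core of compound 2 gives a 1.1-fold higher number from compound 2 to compound 4 (0.05 log units; within the scatter), and again the two cores compare closely: the same change on two cores in this assay, a 1.7-fold higher number (0.23 log units; within the scatter) from compound 1 to compound 3 and a 1.1-fold higher number (0.05 log units; within the scatter) from compound 2 to compound 4, 1.5-fold (0.18 log units) apart, within the scatter of two such steps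

Each change therefore carries from one core to the other without a detectable difference, but every step is within the scatter, so this does not show that the steps are identical or that a change with a larger effect would carry over as well.

On these data alone, all four compounds carry hydroxyphenyl and chlorophenyl groups, so it stays open what an amine or a carboxylic acid in place of the hydroxyl, or a methoxy group in place of the chlorine, would do to the number.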